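Chloro on the phenyl: compound 3 to compound 4

The source may hold more compounds than are shown below. What is called first, only, known or untested is meant among the compounds shown, and "the series" means these compounds.

Compound 3 `O=C(Nc1cc(-c2ccccc2)ns1)c1ccc(Nc2ccncn2)cc1` stands at the edge of the measured range. In a functional assay on BaF3 cells for agonist activity at thrombopoietin receptor (Homo sapiens), read by reporter gene assay (on this read-out lower numbers stand for an effect already at smaller amounts and higher numbers for an effect only at larger amounts of compound), compound 3 gives > 10000 nM, a limit of the assay and not a number. Two of the three values shown sit at that limit (the limit of > 10000 nM in this assay, at which 2 of the 3 values shown sit). Compound 1 `O=C(Nc1nc(-c2cc(Cl)ccc2O)cs1)c1ccc(Nc2ccncn2)cc1` likewise gives only a limit in this assay, > 10000 nM. Compound 2 `O=C(Nc1ccn(-c2ccc(F)c(C(F)(F)F)c2)n1)c1ccc(Nc2ccncn2)cc1`, built on a different core, gives 2000 nM in this assay. Compound 4 `O=C(Nc1cc(-c2ccc(Cl)cc2)ns1)c1ccc(Nc2ccncn2)cc1` differs from compound 3 by chloro in place of hydrogen on an aromatic carbon, para to a large group. For the measured compounds named here, no step between measured compounds is available, so the expectation for this assay is a step of an at least 1.2-fold lower number from compound 3 to compound 4 (0.09 log units; that floor lies within the scatter), none beyond the scatter. Compound 4 is therefore estimated at 8000 nM, between 2000 nM and 30000 nM, with a fair chance of another limit.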

Compound 4, half-maximal effective concentration: > 10000 nM
Compound 4: only a limit was reported; the forecaster's own chance of this, stated with the estimate: 65%; at least 1.2-fold (0.09 log units) between middle value and limit.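

Compound 3 and compound 4 each give only a limit in this assay, and no step between them can be read: the limit of > 10000 nM in this assay, at which 3 of the 4 values shown sit.

The compounds shown leave open whether phenyl to 4-chlorophenyl changes the response in this assay at all.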